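Bromine on the Pyrimidine Ring of an Endothelin Antagonist

A few compounds are considered here, and "the series" means these few. Any claim that something is new, unique, unknown or untested is made for them only; others in the source may bear on it.

Compound 1 `COc1cccc(Oc2c(NS(=O)(=O)c3ccc(C(C)(C)C)cc3)ncnc2OCCO)c1` and compound 2 `COc1cccc(Oc2c(NS(=O)(=O)c3ccc(C(C)(C)C)cc3)ncnc2OCCOc2ncccn2)c1` were both tested in an assay on cells (Endothelial cell) for binding affinity to Endothelin-1 receptor (Sus scrofa); a higher number here means a weaker inhibitor, a lower number a stronger inhibitor. Compound 1 gives 160 nM, and compound 2 gives 1.9 nM, the lowest of the two numbers, the step being an 84-fold lower number from compound 1 to compound 2 (1.93 log units; beyond the scatter). Compound 3 `COc1cccc(Oc2c(NS(=O)(=O)c3ccc(C(C)(C)C)cc3)ncnc2OCCOc2ncc(Br)cn2)c1` is not yet measured. It differs from compound 2 by bromo in place of hydrogen on an aromatic carbon: the bromine sits on an aromatic carbon of the six-membered ring with two nitrogens, two atoms from the ring nitrogen and para to a large group. Among the compounds with values here, the only measured step concerns the pyrimidin-2-yl group itself, not a substituent on it, so no measured step bears directly on this change. For compound 3 in this assay a step of a 1.3-fold lower number from compound 2 to compound 3 (0.10 log units; within the scatter) is therefore expected, which lies within the scatter, and the estimate for compound 3 is 1.5 nM, with a range from 0.4 nM to 6 nM.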

Compound 3, half-maximal inhibitory concentration: 0.051 nM
Compound 3: the middle estimate sits 29-fold (1.47 log units) above what was measured; the whole stated range lies above it.
By their numbers in this assay, from the lowest: compound 3; then compound 2; then compound 1.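

A single bromo on an aromatic carbon of the pyrimidine ring, two atoms from the ring nitrogen, gives a 37-fold lower number from compound 2 to compound 3 (1.57 log units; beyond the scatter) in this assay. Within the data shown here, until now, the data showed only that adding the pyrimidin-2-yl group mattered; this step shows that a substituent on that group can matter greatly too. Taken whole, the 5-bromopyrimidin-2-yl group gives a 3100-fold lower number from compound 1 to compound 3 (3.50 log units; beyond the scatter), and the bromo step is large in its own right, as is an 84-fold lower number from compound 1 to compound 2 (1.93 log units; beyond the scatter).

Nothing available here explains why bromo has this effect. The compounds shown also leave open whether the gain is particular to bromine, or whether chlorine, a methyl group or an amine on this same carbon would give a similar result.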